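The source may hold more compounds than are shown below. What is called first, only, known or untested is meant among the compounds shown, and "the series" means these compounds.

Measured compounds in a functional assay on MKN-45 cells (Homo sapiens) for cytotoxicity, read by MTT assay, with a stated time of 72 h; on this read-out lower numbers stand for stronger inhibition and higher numbers for weaker inhibition:
compound 1 `Cc1ccc(NC(=O)Nc2ccc(-c3nc(NCCN(C)C)c4sccc4n3)cc2)cc1`, 2380 nM
compound 2 `CCN(CC)CCCNc1nc(-c2ccc(NC(=O)Nc3ccccc3F)cc2)nc2ccsc12`, 580 nM
compound 3 `CCN(CC)CCCNc1nc(-c2ccc(NC(=O)Nc3ccccc3Cl)cc2)nc2ccsc12`, 390 nM

Compound 3 gives the lowest of the three numbers in this assay. Its nearest neighbour is compound 2, and a 1.5-fold lower number from compound 2 to compound 3 (0.17 log units; within the scatter) lies within the scatter, so the two cannot be ordered. Among the measured compounds shown here, compound 1 sits apart from compound 3 beyond the scatter, but compound 1 also carries a different amine chain on the shared core, so no single-point step links it to compound 3.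

Compound 4 `CCN(CC)CCCNc1nc(-c2ccc(NC(=O)Nc3ccc(C)cc3)cc2)nc2ccsc12` is not yet measured. It differs from compound 3 by 4-methylphenyl in place of 2-chlorophenyl on an amide-type nitrogen. For the measured compounds named here, only one measured step touches the same position, a 1.5-fold lower number from compound 2 to compound 3 (0.17 log units; within the scatter), which is within the scatter and exchanges one halogen for another rather than changing the substitution pattern. Going by the values given here, compound 1 is the only compound bearing the same 4-methylphenyl group, and compound 3 and compound 1 differ in the chain as well, so the value of compound 1 in this assay, 2380 nM, is only a loose guide. A moderate upward step in this assay is nevertheless expected, a 2.3-fold higher number from compound 3 to compound 4 (0.36 log units; beyond the scatter), with wide uncertainty. For compound 4 the estimate in this assay is 900 nM, with a range of 350 nM to 2500 nM.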

Compound 4, half-maximal inhibitory concentration: 1760 nM
Compound 4: the middle estimate sits 2.0-fold (0.29 log units) below what was measured; the measured number falls inside the stated range.
By their numbers in this assay, from the lowest: compounds 3 and 2 (each within the scatter of the next); then compounds 4 and 1 (each within the scatter of the next).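

In this assay, among the compounds shown here, the aryl group on the amide-type nitrogen now shows steps beyond the scatter, a 4.5-fold higher number from compound 3 to compound 4 (0.65 log units; beyond the scatter) and a 3.0-fold higher number from compound 2 to compound 4 (0.48 log units; beyond the scatter), whereas the only earlier step at this position, a 1.5-fold lower number from compound 2 to compound 3 (0.17 log units; within the scatter), could not be ordered. Among the compounds carrying the diethylamino chain, 4-methylphenyl therefore gives a higher number than either 2-chlorophenyl or 2-fluorophenyl, so this position responds to a change of aryl group more than the exchange of one halogen for another had shown. With 4-methylphenyl held constant, the chain exchange gives a 1.4-fold lower number from compound 1 to compound 4 (0.13 log units; within the scatter), so the two chains cannot be ordered in this pair.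

The step from 2-chlorophenyl to 4-methylphenyl changes both the substituent and its place on the ring, and separating the two would take compounds such as the 2-methylphenyl and 4-chlorophenyl analogues on the same nitrogen, with unsubstituted phenyl as a reference. No evidence is available on what lies behind the higher numbers of compound 4 at this position.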